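The compounds below may be only part of what the source reports. "The series", "measured", "known", "first", "only" and "open" are said of these compounds alone.

Compound 1 `O=C(CN(c1nc(Cl)nc2[nH]cnc12)C1CC1)N[C@@H](CO)C(=O)OCc1ccccc1` is the reference point. In a functional assay on the whole organism (Tail, strain ICR) with Mus musculus as the target, in the tail flick test, with a stated time of 150 min, at a dose of 25 umol/kg by the oral route (a higher number here means a stronger effect of the compound at the dose given, a lower number a weaker effect), compound 1 gives 27.9%, the highest of the three numbers measured. Compound 3 `O=C(CN(c1nc(Cl)nc2[nH]cnc12)C1CC1)N[C@@H](CO)C(=O)O` differs from it in a single place, and compound 3 gives 18.8%; the step of a number 9.1 percentage points lower from compound 1 to compound 3 (within the scatter) stays within the scatter. Compound 2 `NC(=O)CC[C@H](NC(=O)CN(c1ncnc2c1ncn2C1CCCCO1)C1CC1)C(=O)OCc1ccccc1` differs from compound 1 in several places at once; compound 2 gives 10.7%, which lies beyond the scatter below the number of compound 1. The unmeasured compound 4 `O=C(CN(c1nc(Cl)nc2[nH]cnc12)C1CC1)N[C@@H](CCC(=O)OCc1ccccc1)C(=O)OCc1ccccc1` alters compound 1 in one place: (benzyloxycarbonyl)methyl in place of hydroxy on a saturated chain carbon, two bonds along the chain from an amide-type nitrogen and a carbonyl carbon. Among the compounds with values here, no measured step touches that position. Within the data shown here, the only single-place step known, a number 9.1 percentage points lower from compound 1 to compound 3 (within the scatter), changed a different part of the molecule and stayed within the scatter, so nothing measured points to a shift beyond the scatter for compound 4, while nothing rules one out either. The expectation for compound 4 is therefore a step of a number 2.9 percentage points lower from compound 1 to compound 4 (within the scatter) that stays within the scatter. Compound 4 is estimated to give 25% in this assay, with a range from 8% to 45%.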

Compound 4, a percentage reported as activity, at one dose (the size of the read-out at that dose, not a potency): 44.5%
Compound 4: middle estimate off by 19.5 percentage points, on the low side; low and high end bracket the measured number.
By their numbers in this assay, from the lowest: compounds 2, 3 and 1 (each within the scatter of the next, the first and the last beyond it); then compound 4.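

The position on the saturated chain carbon turns out to matter: in this assay the change gives a number 16.6 percentage points higher from compound 1 to compound 4 (beyond the scatter), the first single-place step shown to go beyond the scatter. Hydroxy can therefore give way to the far larger (benzyloxycarbonyl)methyl, with its added aromatic ring, without losing the effect at this one dose, and the effect in fact rises. Nothing measured here explains why the number goes up.

The compounds shown do not separate the contribution of the longer chain from that of the benzyl ester at its end, so a plain propyl chain or a chain ending in a carboxylic acid or an amine would be informative. From the compounds shown here alone, it also remains open whether the rise holds at other doses and times.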